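Nitro for bromo on the benzylsulfanyl arm of compound 3

The source may report more compounds than this note shows. Statements on the series, on what has been measured and on what is new or still open speak of the compounds shown alone.

Measured compounds:
- compound 1, `Cc1cc(N2CC[C@@H](C)[C@@H](N(C)c3ncnc4[nH]ccc34)C2)n2ncnc2n1`: 67400 nM
- compound 2, `Cc1cc(N2CC[C@@H](C)[C@@H](N(C)c3ncnc4[nH]ccc34)C2)n2nc(SCc3ccccc3Br)nc2n1`: 81100 nM
- compound 3, `Cc1cc(N2CC[C@@H](C)[C@@H](N(C)c3ncnc4[nH]ccc34)C2)n2nc(SCc3ccc(Br)cc3)nc2n1`: 28000 nM

All three share one core and were tested in a functional assay on BGC-823 cells (Homo sapiens) for inhibition, read by MTT assay, with a stated time of 72 h; on this read-out higher numbers stand for weaker inhibition and lower numbers for stronger inhibition. Compound 3 gives the lowest number of the three: the step of a 2.4-fold lower number from compound 1 to compound 3 (0.38 log units; beyond the scatter) and the step of a 2.9-fold lower number from compound 2 to compound 3 (0.46 log units; beyond the scatter) are both beyond the scatter, while a 1.2-fold higher number from compound 1 to compound 2 (0.08 log units; within the scatter) is not. Compound 3 therefore stands as the strongest inhibitor among the measured compounds.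

Compound 4, `Cc1cc(N2CC[C@@H](C)[C@@H](N(C)c3ncnc4[nH]ccc34)C2)n2nc(SCc3ccc([N+](=O)[O-])cc3)nc2n1`, keeps everything of compound 3 except the change (nitro in place of bromo on an aromatic carbon). Going by the values given here, no measured step touches this position in the same way: the two steps that are known concern the arm being present at all (compound 1 to compound 3) and the position of bromo on the phenyl ring (compound 2 to compound 3), not a swap of the group itself. The comparison of compound 2 with compound 3 shows that the phenyl substituent does matter in this assay, but gives no direction for nitro. The expectation for compound 4 is thus a step of a 1.1-fold higher number from compound 3 to compound 4 (0.03 log units; within the scatter), close to no change beyond the scatter. Compound 4 is estimated at 30000 nM, with a range from 12000 nM to 75000 nM.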

Compound 4, half-maximal inhibitory concentration: 59600 nM
The estimate for compound 4 lay 2.0-fold (0.30 log units) below the measured number; low and high end bracket the measured number.
By their numbers in this assay, from the lowest: compound 3; then compounds 4, 1 and 2 (each within the scatter of the next).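

In this assay, going by these compounds alone, a 2.1-fold higher number from compound 3 to compound 4 (0.33 log units; beyond the scatter) gives the first direct reading of a group swap on this aromatic carbon: the 4-bromobenzyl and 4-nitrobenzyl arms are not interchangeable, and bromo gives the stronger inhibition of the two. The arm alone does not carry the gain seen with compound 3, since the (4-nitrobenzyl)sulfanyl arm leaves a 1.1-fold lower number from compound 1 to compound 4 (0.05 log units; within the scatter) within the scatter, and a 1.4-fold lower number from compound 2 to compound 4 (0.13 log units; within the scatter) also stays within it. Nothing measured here accounts for the difference between bromo and nitro.

As far as these compounds go, with only bromo and nitro at this place, it remains open whether the reading follows a halogen as such; chloro, fluoro, methyl or an amine on the same carbon would test this. Also open, from the compounds shown here alone, is how a carboxylic acid there would read in this assay.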